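The source may report more compounds than this note shows. Statements on the series, on what has been measured and on what is new or still open speak of the compounds shown alone.

For the measured compounds named here, compound 3, with the structure `CCCCn1cnc2c(Nc3ccccc3)nc(NCOCc3ccc(C(=O)Nc4ccccc4N)cc3)nc21`, stands highest among the three compounds measured so far in a functional assay on HCT-116 cells (Homo sapiens) for antiproliferative activity, read by CCK-8 assay, with a stated time of 72 h, tested at 8 uM (a lower number here means a weaker effect, a higher number a stronger effect of the compound at the concentration tested), where compound 3 gives 74.9%. The nearest of the others is compound 2, with the structure `CC(C)n1cnc2c(Nc3cccc(Cl)c3)nc(NCOCc3ccc(C(=O)Nc4ccccc4N)cc3)nc21`, which in this assay gives 63.4%, a gap beyond the scatter. Furthest away is compound 1, with the structure `CCCCn1cnc2c(Nc3cccc(Cl)c3)nc(NCOCc3ccc(/C=C/C(=O)Nc4ccccc4N)cc3)nc21`, which in this assay gives only 10.9%.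

Compound 4, with the structure `CCCCn1cnc2c(Nc3cccc(Cl)c3)nc(NCOCc3ccc(C(=O)Nc4ccccc4N)cc3)nc21`, has not yet been measured in this assay. It differs from compound 3 in a single respect: chloro in place of hydrogen on an aromatic carbon, on an aromatic carbon of a six-membered aromatic ring of carbon only, meta to a large group. Compound 2 also carries a chloro group on that ring and gives 63.4%, so a moderate weakening is expected, with a step of a number 9.9 percentage points lower from compound 3 to compound 4 (within the scatter) from compound 3 to compound 4 that may reach just beyond the scatter. Compound 4 is therefore estimated to give 65% in this assay, with a likely range from 45% to 80%.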

Compound 4, a percentage reported as inhibition, at one concentration (the size of the read-out at that concentration, not a potency): 71.9%
Estimate against measurement, compound 4: 6.9 percentage points below, and the stated range covers the measured number.
By their numbers in this assay, from the lowest: compound 1; then compounds 2, 4 and 3 (each within the scatter of the next, the first and the last beyond it).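

In this assay, the 3-chlorophenyl group of compound 4 cannot be told apart from the phenyl group of compound 3: chloro in place of hydrogen on the aromatic carbon gives a number 3 percentage points lower from compound 3 to compound 4 (within the scatter). Butyl in place of isopropyl on the aromatic nitrogen gives a number 8.5 percentage points higher from compound 2 to compound 4 (within the scatter), also a small step, whereas (2-aminophenyl)carbamoyl in place of 2-((2-aminophenyl)carbamoyl)ethenyl gives a number 61 percentage points higher from compound 1 to compound 4 (beyond the scatter), so among these compounds the one large step goes with that change alone. No measurement offered here explains any of these steps.

Going by these compounds, whether a different group on this ring, such as fluoro, methoxy or an amine, would move the number beyond the scatter remains open. On these data alone, each number comes from a single concentration, so these numbers compare the effect of the compounds at that concentration only; how their effects compare at other concentrations remains open.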